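Configuration of the exocyclic double bond in compound 3

The source may hold more compounds than are shown below. What is called first, only, known or untested is meant among the compounds shown, and "the series" means these compounds.

Compound 1 `C=C(Br)C(=O)Nc1ccc2c(c1)/C(=C\c1cccs1)C(=O)N2`: 710 nM
Compound 2 `C=C(Br)C(=O)Nc1ccc2c(c1)/C(=C\c1ccsc1)C(=O)N2`: 96 nM

Of the compounds shown here, two have been measured in a functional assay on CCRF-CEM cells (Homo sapiens) for antiproliferative activity, read by MTT assay, with a stated time of 72 h; on this read-out lower numbers stand for stronger inhibition and higher numbers for weaker inhibition. Compound 1 `C=C(Br)C(=O)Nc1ccc2c(c1)/C(=C\c1cccs1)C(=O)N2` gives 710 nM. Compound 2 `C=C(Br)C(=O)Nc1ccc2c(c1)/C(=C\c1ccsc1)C(=O)N2` gives 96 nM in this assay, the lowest of the two numbers; its nearest neighbour is compound 1, and the change from compound 1 to compound 2 was a 7.4-fold lower number from compound 1 to compound 2 (0.87 log units; beyond the scatter) in this assay, a modest step beyond the scatter.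

Compound 3 `C=C(Br)C(=O)Nc1ccc2c(c1)/C(=C/c1ccsc1)C(=O)N2` has not yet been measured in this assay. It differs from compound 2 as follows: the two compounds have the same atoms and bonds and differ only in configuration as drawn: 1 of 1 stereo elements differ; a double bond is drawn E in compound 2 and Z in compound 3. Within the data shown here, no measured step bears on such a change, since the single step from compound 1 to compound 2 altered the thiophene attachment and not the double-bond geometry. Without a precedent the expected step from compound 2 to compound 3 in this assay is small, a 1.6-fold higher number from compound 2 to compound 3 (0.19 log units; within the scatter), with no direction that the data can justify and a wide range on either side. Compound 3 is therefore estimated at 150 nM, between 40 nM and 700 nM.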

Compound 3, half-maximal inhibitory concentration: 4 nM
For compound 3 the middle estimate is 38-fold (1.57 log units) above the measured one, and the stated range ends above it.
By their numbers in this assay, from the lowest: compound 3; then compound 2; then compound 1.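

The double bond itself turns out to be a strong determinant of the result in this assay, which the earlier pair could not show, as both of its compounds are drawn E. Moving from E to Z with the thiophen-3-yl group kept in place gives a 24-fold lower number from compound 2 to compound 3 (1.38 log units; beyond the scatter), a larger step than the earlier change of thiophene attachment, which gave a 7.4-fold lower number from compound 1 to compound 2 (0.87 log units; beyond the scatter). The step can be assigned to the double-bond geometry alone, and not to any change of group, because nothing else separates the pair: the fact that compounds 2 and 3 differ only in the configuration as drawn.

With only one E and Z pair shown, the compounds leave open whether the Z form would give a similar step with the thiophen-2-yl group of compound 1, or with a phenyl or furan-3-yl group in place of the thiophene. They also leave open whether the low number of compound 3 would survive replacing the bromine on the amide chain with chlorine or hydrogen.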